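Replacing the benzyl amide of compound 3 with a methoxyphenyl amide

The source may report more compounds than this note shows. Statements on the series, on what has been measured and on what is new or still open speak of the compounds shown alone.

This series shares one core, shown in compound 1 `COc1ccc2c(=O)c(/C=C/C(=O)Nc3cccc(C)c3)coc2c1`, compound 2 `COc1ccc2c(=O)c(/C=C/C(=O)Nc3cccc(Cl)c3)coc2c1` and compound 3 `COc1ccc2c(=O)c(/C=C/C(=O)NCc3ccc(F)cc3)coc2c1`, and differs only at the amide nitrogen. In a functional assay on A549 cells (Homo sapiens) for inhibition, read by MTT assay, with a stated time of 48 h (on this read-out lower numbers stand for stronger inhibition and higher numbers for weaker inhibition), compound 3 reaches only the limit of the assay, at > 100000 nM. Compound 1 likewise sits at a limit in this assay, at > 100000 nM. Compound 2 gives 470 nM in this assay. The step of an at least 210-fold higher number from compound 2 to compound 3 (2.32 log units; beyond the scatter) is therefore large, while the step that the two limits leave unreadable from compound 1 to compound 3 cannot be read from two limits; the related step of an at least 210-fold lower number from compound 1 to compound 2 (2.32 log units; beyond the scatter) shows how strongly the group on the amide nitrogen matters. Compound 4 `COc1ccc2c(=O)c(/C=C/C(=O)Nc3ccccc3OC)coc2c1` carries the change (2-methoxyphenyl in place of 4-fluorobenzyl on an amide-type nitrogen). Compound 4 returns to an aryl amide, as in compound 1 and compound 2, but with a group neither has tested, so the expected step of an at least 5.0-fold lower number from compound 3 to compound 4 (0.69 log units; beyond the scatter) is uncertain in size, with a lower number thought more likely than not. Compound 4 is estimated at 20000 nM in this assay, within a wide range from 1000 nM to 100000 nM.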

Compound 4, half-maximal inhibitory concentration: > 100000 nM
Compound 4 gave a limit, no number; the forecaster's own chance of this, stated with the estimate: 45%; middle value at least 5.0-fold (0.69 log units) from the limit.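

Compound 4 shows that the 3-chlorophenyl amide of compound 2 cannot be swapped for just any aryl amide in this assay: 2-methoxyphenyl on the amide-type nitrogen gives an at least 210-fold higher number from compound 2 to compound 4 (2.32 log units; beyond the scatter). Compound 2 thus remains the only one of the four compounds with a number rather than a limit, and its 3-chlorophenyl group is the only amide group shown here to give one. The steps among compound 1, compound 3 and compound 4 cannot be read, because all three values end at the same point: the limit of > 100000 nM in this assay, at which 3 of the 4 values shown sit.

Going by these compounds, it remains open whether a bromo or trifluoromethyl group in place of the chloro on the aromatic carbon would keep a measurable value. On these data alone, the effect of an amine or a carboxylic acid on that aryl ring is also open.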